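Swapping 2-methoxyphenyl for 3-chloropropyl in an inactive series

The source may report more compounds than this note shows. Statements on the series, on what has been measured and on what is new or still open speak of the compounds shown alone.

In a functional assay on HCT-116 cells (Homo sapiens) for antiproliferative activity, read by MTT assay, with a stated time of 72 h (on this read-out lower numbers stand for stronger inhibition and higher numbers for weaker inhibition), compound 1 `CC(C)(C)OC(=O)N1CCN(C(=S)SCc2cn(C[C@H](O)[C@H]3OC(=O)C(OCc4ccccc4)=C3OCc3ccccc3)nn2)CC1` gives > 100000 nM, which is a limit of the assay. Compound 2 `COc1ccccc1-c1cn(C[C@H](O)[C@H]2OC(=O)C(OCc3ccccc3)=C2OCc2ccccc2)nn1` gives > 100000 nM, also a limit. Compound 3 `COc1ccc(-c2cn(C/C=C3\OC(=O)C(OCc4ccccc4)=C3OCc3ccccc3)nn2)cc1` gives > 100000 nM, again a limit. Compound 2 therefore has no exact number and stands level with the other two, the evidence being (the limit of > 100000 nM in this assay, at which 3 of the 3 values shown sit).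

Compound 4 `O=C1O[C@H]([C@@H](O)Cn2cc(CCCCl)nn2)C(OCc2ccccc2)=C1OCc1ccccc1` carries 3-chloropropyl in place of 2-methoxyphenyl on an aromatic carbon. For the measured compounds named here, no step between measured compounds is available, so any expectation in this assay is weakly grounded. A small move toward stronger inhibition is expected, or none beyond the scatter. The expected change is an at least 1.6-fold lower number from compound 2 to compound 4 (0.22 log units; that floor lies within the scatter). For compound 4 the estimate is 60000 nM, with an expected range of 15000 nM to 150000 nM.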

Compound 4, half-maximal inhibitory concentration: 36100 nM
Estimate against measurement, compound 4: 1.7-fold (0.22 log units) above, and the stated range covers the measured number.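

In this assay, 3-chloropropyl at this aromatic carbon gives the only exact number among the compounds shown, and the change reads as an at least 2.7-fold lower number from compound 2 to compound 4 (0.44 log units; beyond the scatter). The shared core can therefore show measurable inhibition when this position carries a ring-free chain rather than 2-methoxyphenyl. Compound 2 has only a limit, so the true size of the step stays open: the limit of > 100000 nM in this assay, at which 3 of the 4 values shown sit.

Whether the chlorine or the chain itself accounts for the difference remains open. A plain propyl group, or an amine in place of the chlorine, would separate the two.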